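From phenyl to 4-cyanophenyl: a first expectation

The source may report more compounds than this note shows. Statements on the series, on what has been measured and on what is new or still open speak of the compounds shown alone.

Among the compounds with values here, only two compounds have numbers so far. In a functional assay on KB cells (Homo sapiens) for inhibition, with a stated time of 72 h (on this read-out higher numbers stand for weaker inhibition and lower numbers for stronger inhibition), compound 1 `COc1ccc(S(=O)(=O)N2CCc3cccc(-c4cccnc4)c32)cc1` reads 95.9 nM while compound 2 `COc1ccc(S(=O)(=O)N2CCc3cccc(-c4ccccc4)c32)cc1` reads 120 nM and the two cannot be told apart. Within the data shown here, compound 2 therefore stands level with its only neighbour. Compound 3 `COc1ccc(S(=O)(=O)N2CCc3cccc(-c4ccc(C#N)cc4)c32)cc1` alters compound 2 in one place: cyano in place of hydrogen on an aromatic carbon and so phenyl becomes 4-cyanophenyl, with cyano in place of hydrogen on an aromatic carbon. Among the measured compounds shown here, one measured step bears on this, the swap of pyridin-3-yl for phenyl, a 1.3-fold higher number from compound 1 to compound 2 (0.10 log units; within the scatter) and it stays within the scatter. That step involves no cyano group, so it is only weak guidance. No step beyond the scatter is therefore expected in this assay and the estimated change is a 1.3-fold higher number from compound 2 to compound 3 (0.10 log units; within the scatter) for now. Compound 3 is expected near 150 nM with an estimated range from 50 nM to 450 nM until it is measured.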

Compound 3, half-maximal inhibitory concentration: 31.1 nM
The estimate for compound 3 lay 4.8-fold (0.68 log units) above the measured number, outside the stated range (below it).
By their numbers in this assay, from the lowest: compound 3; then compounds 1 and 2 (each within the scatter of the next).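

Within the data shown here, this aromatic carbon, para to a large group, is the first place where a single change moves the number beyond the scatter: in this assay, putting cyano in place of hydrogen gives a 3.9-fold lower number from compound 2 to compound 3 (0.59 log units; beyond the scatter) and so stronger inhibition. The 4-cyanophenyl group also separates from pyridin-3-yl, with a 3.1-fold lower number from compound 1 to compound 3 (0.49 log units; beyond the scatter) in the same read-out, whereas phenyl and pyridin-3-yl could not be told apart. No measurement here accounts for this difference.

Still open, on these data alone, is whether this shift is particular to cyano or would also appear with another group at the same carbon, such as an amine, a carboxylic acid or a chlorine atom. The compounds shown also leave open how cyano would behave at any other carbon of this ring.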